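Replacing the amide end group on the longer chain

A few compounds are considered here, and "the series" means these few. Any claim that something is new, unique, unknown or untested is made for them only; others in the source may bear on it.

Compound 1, `CCCOc1ccc(NC(=O)CSc2nnc(Cc3nn(C)c(=O)c4ccccc34)n2C)cc1`, in an assay on isolated protein (Mus musculus) for inhibition of IL15-IL15 receptor (Homo sapiens), read by resazurin assay, with stated times of 30 min and 2.5 days (on this read-out lower numbers stand for stronger inhibition and higher numbers for weaker inhibition), gives > 30000 nM, which is a limit of the assay and not a number.
Compound 2, `CCCOc1ccc(NC(=O)CCCCCCCSc2nnc(Cc3nn(C)c(=O)c4ccccc34)n2C)cc1`, gives 1600 nM.
Compound 3, `COc1ccc(NC(=O)CSc2nnc(Cc3nn(C)c(=O)c4ccccc34)n2C)cc1`, is reported as "not active" (no number reported), with no number attached.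

Among the measured compounds shown here, compound 2 therefore carries the only actual number here; compound 1 sits at the limit of > 30000 nM in this assay, at which 1 of the 3 values shown sits, and compound 3 has no figure at all. Compound 4, `CN(C(=O)CCCCCCCSc1nnc(Cc2nn(C)c(=O)c3ccccc23)n1C)c1ccc(Cl)cc1Cl`, has not been measured. It differs from compound 2 in a single place: (2,4-dichlorophenyl)(methyl)amino in place of (4-propoxyphenyl)amino on a carbonyl carbon. For the measured compounds named here, no pair of measured compounds shows what this kind of exchange at the end of the amide does, so the present data give no direct guide, and the swap is treated as one of unknown size. The expectation is a change no larger than the usual scatter, a 1.3-fold higher number from compound 2 to compound 4 (0.10 log units; within the scatter), in either direction. Compound 4 is estimated at 2000 nM, with a range from 500 nM to 10000 nM.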

Compound 4, half-maximal inhibitory concentration: 11900 nM
Compound 4: middle estimate off by 6.0-fold (0.77 log units), on the low side, and the stated range ends below it.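

The end of the amide on the longer chain is a place where an exchange can matter: in this assay, putting (2,4-dichlorophenyl)(methyl)amino in place of (4-propoxyphenyl)amino gives a 7.4-fold higher number from compound 2 to compound 4 (0.87 log units; beyond the scatter). Among the compounds shown here, this is the only step in the set that can be read as a number, so a swap of previously unknown size now has a measured size, and that size lies beyond the usual scatter. The top of the scale remains the entry of compound 1, which is a limit and not a number: the limit of > 30000 nM in this assay, at which 1 of the 4 values shown sits.

The exchange alters the groups on the ring and also removes the amide hydrogen, and the compounds shown cannot separate these two changes. A (2,4-dichlorophenyl)amino end or a (4-propoxyphenyl)(methyl)amino end on the same chain would tell them apart.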